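Lengthening the link to a chlorophenyl group

The source may hold more compounds than are shown below. What is called first, only, known or untested is meant among the compounds shown, and "the series" means these compounds.

Among the measured compounds shown here, compound 2 `COc1cc(C)c2[nH]cc(/C=N/NC(=N)NCc3ccc(Cl)cc3)c2c1` is one of two compounds measured in a functional assay on CHO-K1 cells for agonist activity at relaxin-3 receptor 1 (Homo sapiens), read by TR-FRET and cAMP accumulation, with a stated time of 1.5 h; a lower number here means a smaller maximal response, a higher number a larger maximal response. For the measured compounds named here, compound 2 gives 99%, and of the two numbers this is the higher, though its only neighbour, compound 1 `COc1cc(C)c2[nH]cc(/C=N/NC(=N)Nc3ccc(Cl)cc3)c2c1`, gives 95%, and the two sit within the scatter of each other. Going by the values given here, the single measured step, a number 4 percentage points higher from compound 1 to compound 2 (within the scatter), came from putting 4-chlorobenzyl in place of 4-chlorophenyl on an amine nitrogen. Compound 3 `COc1cc(C)c2[nH]cc(/C=N/NC(=N)NCCCc3ccc(Cl)cc3)c2c1` has not yet been measured. It differs from compound 2 by 2-(4-chlorophenyl)ethyl in place of 4-chlorophenyl on a saturated chain carbon bound to an amine nitrogen. Among the compounds with values here, this change again only lengthens the link between the amine nitrogen and the chlorophenyl ring, just as the one measured step did. Because that step was a number 4 percentage points higher from compound 1 to compound 2 (within the scatter), no step beyond the scatter is expected for compound 3 in this assay, a number 4 percentage points lower from compound 2 to compound 3 (within the scatter). Compound 3 is therefore estimated at 95%, within a range from 80% to 106%.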

Compound 3, largest response reached (Emax), in percent of the reference or control that the assay uses: 82%
Compound 3: middle estimate off by 13 percentage points, on the high side, and the stated range covers the measured number.
By their numbers in this assay, from the lowest: compound 3; then compounds 1 and 2 (each within the scatter of the next).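

Among the compounds shown here, this position tolerated the first change to the link, but not every change. In this assay, the step is a number 17 percentage points lower from compound 2 to compound 3 (beyond the scatter), so the maximal response does respond to what sits on this amine nitrogen, which the step from compound 1 to compound 2 could not show because it stayed within the scatter. Nothing shown here explains the drop.

For the compounds shown here, with only three compounds, it remains open whether a still longer chain would lower the response further or whether compound 3 is close to the limit of what this position accepts. Going by these compounds, it is also open whether an ether oxygen or an amine within the link, or a fluorine in place of the chlorine on the ring, would keep the response of compound 2.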